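The compounds below may be only part of what the source reports. "The series", "measured", "known", "first", "only" and "open" are said of these compounds alone.

Compounds measured so far:

Compound 1, `O=C1C[C@H](O)C[C@@H](/C=C/c2c(Cl)cc(Cl)cc2-c2cc(Cl)cc(Cl)c2)O1`, with 37 nM in an assay for inhibition of 3-hydroxy-3-methylglutaryl-coenzyme A reductase (Rattus norvegicus); a lower number here means a stronger inhibitor, a higher number a weaker inhibitor.
Compound 2, `Cc1ccccc1-c1cc(Cl)cc(Cl)c1/C=C/[C@@H]1C[C@@H](O)CC(=O)O1`, with 370 nM.
Compound 3, `O=C1C[C@H](O)C[C@@H](/C=C/c2c(Cl)cc(Cl)cc2-c2ccc(Cl)c(Cl)c2)O1`, with 25 nM.

Compound 3 gives the lowest number of the three; compound 1 sits within the scatter of it, while compound 2 lies far higher. Compound 4, `O=C1C[C@H](O)C[C@@H](/C=C/c2c(Cl)cc(Cl)cc2-c2cccc(F)c2)O1`, carries 3-fluorophenyl in place of 3,4-dichlorophenyl on an aromatic carbon. Among the measured compounds shown here, two measured steps bear on this: a 1.5-fold lower number from compound 1 to compound 3 (0.17 log units; within the scatter), and a 15-fold lower number from compound 2 to compound 3 (1.17 log units; beyond the scatter). Swapping one dichlorophenyl for another changed little, whereas a single small substituent on that ring cost much. A lone fluorine is closer to the second case, so compound 4 is expected to give a higher number, a 3.2-fold higher number from compound 3 to compound 4 (0.51 log units; beyond the scatter). The estimate for compound 4 is 80 nM, within 25 nM to 250 nM.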

Compound 4, half-maximal inhibitory concentration: 70 nM
Compound 4: the middle estimate sits 1.1-fold (0.06 log units) above what was measured; the measured number falls inside the stated range.
By their numbers in this assay, from the lowest: compounds 3, 1 and 4 (each within the scatter of the next, the first and the last beyond it); then compound 2.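

In this assay, dropping to a single fluorine on this ring gives a 2.8-fold higher number from compound 3 to compound 4 (0.45 log units; beyond the scatter) and so costs something, yet the comparison with the other dichlorophenyl compound gives a 1.9-fold higher number from compound 1 to compound 4 (0.28 log units; within the scatter) and leaves no clear loss. Two chlorines are therefore not strictly required here, and the 3-fluorophenyl ring also stands clear of the 2-methylphenyl ring, with a 5.3-fold lower number from compound 2 to compound 4 (0.72 log units; beyond the scatter) as the step between them. No measurement shown explains these differences.

From the compounds shown here alone, it remains open how an unsubstituted phenyl or a 3-methoxyphenyl ring would compare at this position, and whether 2-fluorophenyl would behave like 3-fluorophenyl or like 2-methylphenyl.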